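Two substituent changes on one shared bicyclic core

This account rests on a few compounds, and the source may have more. Where it says the series, first, only, none or still open, it means among the compounds named here.

Compound 1 `Cc1ccc(-c2nc3sc(Cc4ccc(Cl)cc4)nn3c2Br)cc1` is the parent of the set. In a functional assay on L1210 cells (Mus musculus) for cytotoxicity, with a stated time of 48 h (a higher number here means a weaker inhibitor, a lower number a stronger inhibitor), compound 1 gives > 250000 nM, which is a limit of the assay and not a number (the limit of > 250000 nM in this assay, at which 1 of the 3 values shown sits). Compound 2 `Clc1ccc(Cc2nn3c(Br)c(-c4ccc(Cl)cc4Cl)nc3s2)cc1` carries the change 2,4-dichlorophenyl in place of 4-methylphenyl on an aromatic carbon and in this assay compound 2 gives 31000 nM, a step of an at least 8.0-fold lower number from compound 1 to compound 2 (0.90 log units; beyond the scatter). Compound 3 `Cc1ccc(-c2nc3sc(Cc4ccc(Cl)cc4)nn3c2SC#N)cc1` differs from compound 1 only in the group on the core: cyanosulfanyl in place of bromo on an aromatic carbon. In this assay compound 3 gives 32000 nM, a step of an at least 7.8-fold lower number from compound 1 to compound 3 (0.89 log units; beyond the scatter). The numbers of compound 2 and compound 3 lie within the usual scatter of each other.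

Compound 4 `N#CSc1c(-c2ccc(Cl)cc2Cl)nc2sc(Cc3ccc(Cl)cc3)nn12` has not yet been measured. It relates to compound 3 as compound 2 relates to compound 1: 2,4-dichlorophenyl in place of 4-methylphenyl on an aromatic carbon. The surroundings of the place differ in one respect: in the pair starting from compound 1 the change sits next to the ring atom that bears a bromo group (1 heavy atom), whereas in the pair starting from compound 3 it sits next to the ring atom that bears a cyanosulfanyl group (3 heavy atoms); so this is the same kind of change, not the same change. The earlier step of an at least 8.0-fold lower number from compound 1 to compound 2 (0.90 log units; beyond the scatter) is known only as a bound, so only its lower end carries over with confidence. The expected step here is a 5.3-fold lower number from compound 3 to compound 4 (0.73 log units; beyond the scatter), resting on that earlier step and on the number of compound 3 32000 nM. Compound 4 is thus estimated at 6000 nM, with a likely range from 1500 nM to 25000 nM.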

Compound 4, half-maximal inhibitory concentration: 49000 nM
Estimate against measurement, compound 4: 8.2-fold (0.91 log units) below, outside the stated range (above it).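

The change to 2,4-dichlorophenyl does not carry from the bromo compounds to the cyanosulfanyl compounds in this assay, where it now gives a 1.5-fold higher number from compound 3 to compound 4 (0.19 log units; within the scatter), and its two readings differ: the same change on two cores in this assay, an at least 8.0-fold lower number (0.90 log units; beyond the scatter) from compound 1 to compound 2 and a 1.5-fold higher number (0.19 log units; within the scatter) from compound 3 to compound 4, at least 12-fold (1.09 log units) apart, beyond the scatter of two such steps

Read the other way, cyanosulfanyl in place of bromo gives a 1.6-fold higher number from compound 2 to compound 4 (0.20 log units; within the scatter) among the 2,4-dichlorophenyl compounds, so that change does not carry either: the same change on two cores in this assay, an at least 7.8-fold lower number (0.89 log units; beyond the scatter) from compound 1 to compound 3 and a 1.6-fold higher number (0.20 log units; within the scatter) from compound 2 to compound 4, at least 12-fold (1.09 log units) apart, beyond the scatter of two such steps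

Compound 1 gives > 250000 nM, a limit of the assay and not a number, so the gap between the steps is known only as a bound, and these four compounds show that the two changes do not add for this one pair of substitutions, not that this holds as a rule across the series.

From the compounds shown here alone, it remains open whether the 2,4-dichlorophenyl step would also vanish with another group on the core in place of bromo or cyanosulfanyl, such as an amine or a carboxylic acid. Going by these compounds, it is equally open whether a ring such as 4-chlorophenyl or 4-methoxyphenyl in place of 4-methylphenyl would follow the same course in this assay.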